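The source may report more compounds than this note shows. Statements on the series, on what has been measured and on what is new or still open speak of the compounds shown alone.

Measured so far in a physicochemical assay for lipophilicity, using the shake flask method, measured as octanol-water partition, at pH 7.4; on this read-out lower numbers stand for lower lipophilicity and higher numbers for higher lipophilicity:

- compound 1 `CC(=O)N[C@@H]1CCC[C@H](C(=O)Nc2cc(-c3cnc(C)n3C(C)C)ccn2)C1`: 1.9
- compound 2 `CC(=O)N[C@@H]1CCC[C@H](C(=O)Nc2cc(-c3cnn(C)c3C)c(Cl)cn2)C1`: 2.6
- compound 3 `CC(=O)N[C@@H]1CCC[C@H](C(=O)Nc2cc(-c3cnc4ccccn34)c(Cl)cn2)C1`: 3

Compound 3 stands highest of these three, with 3. Within the data shown here, compound 2 lies nearest to it, and compound 1 lies furthest away and marks the low end of the numbers so far.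

The next compound is compound 4 `CC(=O)N[C@@H]1CCC[C@H](C(=O)Nc2cc(-c3cnn4c3CN(C)CC4)c(Cl)cn2)C1`, which has not yet been measured. The change from compound 3 is a group of 10 heavy atoms (7 carbon, 3 nitrogen; one five-membered aromatic ring with 2 hetero atoms, one six-membered non-aromatic ring with 2 hetero atoms) in place of a group of 9 heavy atoms (7 carbon, 2 nitrogen; one five-membered aromatic ring with 2 hetero atoms, one six-membered aromatic ring with 1 hetero atom), on an aromatic carbon. It sits on an aromatic carbon of the shared core, ortho to a chloro group and opposite the ring nitrogen.

Among the measured compounds shown here, one measured step bears on this change: a number 0.40 log units higher from compound 2 to compound 3 (beyond the scatter). That step brought in a six-membered aromatic ring with 1 hetero atom, and the group entering compound 4 has a six-membered non-aromatic ring with 2 hetero atoms in its place. For the measured compounds named here, compound 1 differs from the others in more than one place, so it offers no direct step. Read in reverse, this single step points to a lower number in this assay, and the extra nitrogen leads to the expectation of a somewhat larger move, beyond the scatter. The expected change is a number 0.90 log units lower from compound 3 to compound 4 (beyond the scatter). For compound 4 the estimated value is 2.1, with an expected range from 1.6 to 2.6.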

Compound 4, distribution coefficient: 2.1
The estimate for compound 4 equals the measured number at the digits printed, within the range that was stated.
By their numbers in this assay, from the lowest: compounds 1 and 4 (each within the scatter of the next); then compound 2; then compound 3.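

At this place on the shared core, on an aromatic carbon ortho to a chloro group and opposite the ring nitrogen, the earlier compounds had shown only a rise in this assay, with a number 0.40 log units higher from compound 2 to compound 3 (beyond the scatter). Replacing the group with a six-membered aromatic ring by one with a six-membered non-aromatic ring with 2 hetero atoms reverses that direction, giving a number 0.90 log units lower from compound 3 to compound 4 (beyond the scatter). The larger group does not simply raise the number with its added heavy atoms, for the same group also gives a number 0.50 log units lower from compound 2 to compound 4 (beyond the scatter); no measured evidence here accounts for either step.

The compounds shown do not separate the effect of the extra nitrogen from that of replacing the six-membered aromatic ring with a non-aromatic one, since both changes arrive together in the entering group. Going by these compounds, it remains open how this assay would respond to a plain carbon in place of that nitrogen, to an oxygen there, or to an acetyl group in place of the methyl on it.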